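Sulfonate ester series on HT-1080 cells: chain lengthening

This account rests on a few compounds, and the source may have more. Where it says the series, first, only, none or still open, it means among the compounds named here.

Measured compounds:
compound 1 `CCCC(=O)Nc1ccc(S(=O)(=O)Oc2ccccc2I)cc1` 2000 nM
compound 2 `CCCCCC(=O)Nc1ccc(S(=O)(=O)Oc2ccccc2I)cc1` 9600 nM
compound 3 `CCCNC(=O)Nc1ccc(S(=O)(=O)Oc2ccccc2C(C)C)cc1` 680 nM

In a functional assay on HT-1080 cells (Homo sapiens) for antiproliferative activity, read by sulforhodamine B assay, with a stated time of 48 h (on this read-out higher numbers stand for weaker inhibition and lower numbers for stronger inhibition), compound 3 gives the lowest number of the three, with compound 1 nearest and compound 2 furthest. The difference between the core of compound 3 and the core of compound 1 is not broken down here.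

Between compound 1 and compound 2 the change is ethyl in place of hydrogen on a saturated chain carbon, three bonds along the chain from a carbonyl carbon, and it gave a 4.8-fold higher number from compound 1 to compound 2 (0.68 log units; beyond the scatter).

Compound 4 `CCCCCNC(=O)Nc1ccc(S(=O)(=O)Oc2ccccc2C(C)C)cc1` is not yet measured. It differs from compound 3 by ethyl in place of hydrogen on a saturated chain carbon, three bonds along the chain from an amide-type nitrogen, the same kind of change as before, though the place differs: three bonds along the chain from an amide-type nitrogen rather than from a carbonyl carbon.

Because compound 1 to compound 2 showed a 4.8-fold higher number from compound 1 to compound 2 (0.68 log units; beyond the scatter), a step of similar size is expected, a 4.4-fold higher number from compound 3 to compound 4 (0.64 log units; beyond the scatter). Compound 4 is estimated at 3000 nM, with a range of 1200 nM to 8000 nM.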

Compound 4, half-maximal inhibitory concentration: 4700 nM
Compound 4: the middle estimate sits 1.6-fold (0.19 log units) below what was measured, and the stated range covers the measured number.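

In this assay ethyl in place of hydrogen on a saturated chain carbon, three bonds along the chain from an amide-type nitrogen, gave a 6.9-fold higher number from compound 3 to compound 4 (0.84 log units; beyond the scatter) on the core of compound 3. The change carried across the two cores at a similar size: the same change on two cores in this assay, a 4.8-fold higher number (0.68 log units; beyond the scatter) from compound 1 to compound 2 and a 6.9-fold higher number (0.84 log units; beyond the scatter) from compound 3 to compound 4, 1.4-fold (0.16 log units) apart, within the scatter of two such steps. For the compounds shown here, this rests on only two pairs in one assay, and the difference between the cores is not broken down, so it does not show that the step would hold on other cores or for other chain lengths.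

The compounds shown leave open how a longer chain such as heptyl would read on either core. They also leave open how a chain ending in an amine or a carboxylic acid would read.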